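Thiophen-2-yl to thiophen-3-yl on a weak compound

The source may report more compounds than this note shows. Statements on the series, on what has been measured and on what is new or still open speak of the compounds shown alone.

In a functional assay on HepG2 cells (Homo sapiens) for antiproliferative activity, read by XTT assay, with a stated time of 72 h (a higher number here means a weaker inhibitor, a lower number a stronger inhibitor), compound 2 (`CNc1ncnc2c1c(-c1ccco1)cn2[C@@H]1O[C@H](CO)[C@@H](O)[C@H]1O`) gives 850 nM and carries furan-2-yl on the shared core. Compound 3 (`CNc1ncnc2c1c(-c1cccs1)cn2[C@@H]1O[C@H](CO)[C@@H](O)[C@H]1O`) carries thiophen-2-yl, and its > 20000 nM is a limit of the assay, not a number. Compound 1 (`CSc1ncnc2c1c(-c1ccsc1)cn2[C@@H]1O[C@H](CO)[C@@H](O)[C@H]1O`) carries thiophen-3-yl on a core that differs elsewhere, and its > 15000 nM is likewise a limit. Compound 3 is thus one of two compounds known only by a limit.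

Compound 4 (`CNc1ncnc2c1c(-c1ccsc1)cn2[C@@H]1O[C@H](CO)[C@@H](O)[C@H]1O`) differs from compound 3 by one swap, thiophen-3-yl in place of thiophen-2-yl on an aromatic carbon with thiophen-3-yl in place of thiophen-2-yl on an aromatic carbon, so the two have the same atoms, joined differently.

The measured step of an at least 23-fold higher number from compound 2 to compound 3 (1.37 log units; beyond the scatter) was large and replaced furan-2-yl with thiophen-2-yl. It shows that the group at this place can matter, yet it does not compare the two thiophene groups. Weak activity is the expectation here, resting on the limit of compound 3 at > 20000 nM and not on any measured swap between thiophene groups. A small step is therefore expected, an at least 1.6-fold lower number from compound 3 to compound 4 (0.22 log units; that floor lies within the scatter) as estimated, with no clear move beyond the scatter. Compound 4 is estimated at 12000 nM with 2500 nM to 30000 nM as its expected range, and the assay may well report only a limit.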

Compound 4, half-maximal inhibitory concentration: > 20000 nM
Compound 4: only a limit was reported (the forecaster's own chance of this, stated with the estimate: 55%); middle value at least 1.6-fold (0.22 log units) from the limit.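

In this assay, replacing furan-2-yl with thiophen-3-yl gives an at least 23-fold higher number from compound 2 to compound 4 (1.37 log units; beyond the scatter), the same printed size as the step to thiophen-2-yl, so the large loss against furan-2-yl does not depend on which way the thiophene ring is joined to the shared core. The weak result of compound 3 is therefore not peculiar to thiophen-2-yl: with either thiophene group, the methylamino compounds are known only by a limit of the assay, and among the compounds shown only furan-2-yl gives a real number. The steps to compound 4 from compound 3 and from compound 1 cannot be read, because each compares two limits, so the two thiophene groups cannot be ranked and the exchange of methylsulfanyl for methylamino has no size: the limit of > 20000 nM in this assay, at which 2 of the 4 values shown sit.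

The compounds shown leave open whether the measurable activity belongs to furan-2-yl alone or would also appear with furan-3-yl or a phenyl ring on this carbon. They also leave open whether furan-2-yl would keep that activity with methylsulfanyl in place of methylamino.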